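Ethoxycarbonyl in place of hydroxymethyl on compound 1

The source may hold more compounds than are shown below. What is called first, only, known or untested is meant among the compounds shown, and "the series" means these compounds.

In an ADME assay on Vero cells (Chlorocebus sabaeus) for cytotoxicity, read by fluorescence and resazurin assay, with a stated time of 3 days (a higher number here means that more compound is tolerated, a lower number that less compound is tolerated), compound 1 `CC1(C)O[C@H]2O[C@H]([C@@H](CCO)n3cnc4c(N)ncnc43)[C@H](Oc3ccccc3[N+](=O)[O-])[C@H]2O1` gives 51800 nM. This lies within the scatter of compound 2 `CC1(C)O[C@H]2O[C@H]([C@H](CC(=O)O)n3cnc4c(N)ncnc43)[C@H](Oc3ccccc3N)[C@H]2O1` at 67100 nM and of compound 3 `CC1(C)O[C@H]2O[C@H]([C@@H](CCO)n3cnc4c(NCc5ccccc5)ncnc43)[C@H](OCc3ccccc3)[C@H]2O1` at 74900 nM.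

Compound 4 `CCOC(=O)C[C@H]([C@H]1O[C@@H]2OC(C)(C)O[C@@H]2[C@H]1Oc1ccccc1[N+](=O)[O-])n1cnc2c(N)ncnc21` carries ethoxycarbonyl in place of hydroxymethyl on a saturated chain carbon, two bonds along the chain from an aromatic nitrogen and a saturated ring carbon. Within the data shown here, no measured pair isolates a single change, so the only guide is the close grouping of the three values. No shift beyond the scatter is expected in this assay. The estimated step is small, a 1.1-fold higher number from compound 1 to compound 4 (0.03 log units; within the scatter). For compound 4 the expected value is 55000 nM, with an estimated range of 28000 nM to 100000 nM.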

Compound 4, half-maximal cytotoxic concentration: 119000 nM
Beside the measured number, compound 4's estimate is 2.2-fold (0.34 log units) below it; the whole stated range lies below it.
By their numbers in this assay, from the lowest: compounds 1, 2, 3 and 4 (each within the scatter of the next, the first and the last beyond it).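

In this assay, ethoxycarbonyl in place of hydroxymethyl gives a 2.3-fold higher number from compound 1 to compound 4 (0.36 log units; beyond the scatter) on this saturated chain carbon. Among these compounds, this is the first step that isolates a single place, and it shows that a change at this chain position alone can move the number beyond the scatter. As far as these compounds go, whether the step follows from the loss of hydroxymethyl or from the ester as a whole stays open, and a primary amine or an amide at this place would help separate the two. No data bearing on the cause of the step are available.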